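Methoxy addition on the aryl ring of two aminochalcone cores

A few compounds are considered here, and "the series" means these few. Any claim that something is new, unique, unknown or untested is made for them only; others in the source may bear on it.

Measured so far in an ADME assay on CCRF-CEM cells (Homo sapiens) for antiproliferative activity, with a stated time of 48 h; on this read-out lower numbers stand for stronger inhibition and higher numbers for weaker inhibition:
- compound 1 `C=C(Br)C(=O)Nc1ccc(C(=O)/C=C/c2cccc(OC)c2)cc1`: 1800 nM
- compound 2 `C=C(Br)C(=O)Nc1ccc(C(=O)/C=C/c2ccc(OC)c(OC)c2)cc1`: 1600 nM
- compound 3 `COc1ccccc1/C=C/C(=O)c1ccc(N)cc1`: 6300 nM

Compounds 1 and 2 share one core; compound 3 `COc1ccccc1/C=C/C(=O)c1ccc(N)cc1` carries a different one, and the difference between the two cores is not broken down here. Compound 3 has the highest number of the three: compared with compound 1 its value is beyond the scatter, and so is the gap to compound 2.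

Within the first core, the change methoxy in place of hydrogen on an aromatic carbon gave a 1.1-fold lower number from compound 1 to compound 2 (0.05 log units; within the scatter).

Compound 4 `COc1ccc(/C=C/C(=O)c2ccc(N)cc2)c(OC)c1` is compound 3 with the same kind of change, (methoxy in place of hydrogen on an aromatic carbon). The place differs: in compound 2 the entering group is ortho to a methoxy group, in compound 4 it is meta to a methoxy group; in both it is para to a large group.

Going by the values given here, the only measured precedent is the flat step from compound 1 to compound 2, so for compound 4 a step of about a 1.1-fold lower number from compound 3 to compound 4 (0.06 log units; within the scatter) in this assay is expected, resting on a 1.1-fold lower number from compound 1 to compound 2 (0.05 log units; within the scatter). Compound 4 is thus estimated at 5500 nM, with a range from 2500 nM to 12000 nM.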

Compound 4, half-maximal inhibitory concentration: 18000 nM
For compound 4 the middle estimate is 3.3-fold (0.51 log units) below the measured one, and the stated range ends below it.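

In this assay the methoxy change gives a 2.9-fold higher number from compound 3 to compound 4 (0.46 log units; beyond the scatter), so the flat step seen on the core of compound 1 does not carry over to the core of compound 3: the same change on two cores in this assay, a 1.1-fold lower number (0.05 log units; within the scatter) from compound 1 to compound 2 and a 2.9-fold higher number (0.46 log units; beyond the scatter) from compound 3 to compound 4, 3.2-fold (0.51 log units) apart, beyond the scatter of two such steps.

This shows that, across these two cores, the result of the same change cannot be read from one core to the other. It does not show why, as the two steps differ both in core and in place: the entering methoxy in compound 4 is meta to a methoxy group, while in compound 2 it stands elsewhere on the ring, so the two influences cannot be separated here.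

Still open, as far as these compounds go, is whether the higher number of compound 4 follows the core, the place of the entering group, or both. Also open, from the compounds shown here alone, is whether an amine, a hydroxyl group or a longer alkoxy chain entering at the same place would move the number in the same direction as methoxy.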